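Swapping the aromatic ring on a saturated ring carbon

This account rests on a few compounds, and the source may have more. Where it says the series, first, only, none or still open, it means among the compounds named here.

Compound 1 `Oc1ccc(N2CCN(Cc3nc4ccccc4[nH]3)CC2)nc1`: 17 nM
Compound 2 `Cc1cccc(C(=O)NCN2CCC(c3cccc[n+]3[O-])CC2)c1`: 1450 nM
Compound 3 `Cc1cc(F)ccc1NC(=O)CN1CCC(c2cccc[n+]2[O-])CC1`: 405 nM

All three compounds were tested in an assay on HEK293 cells for displacement of a labelled ligand from D(4) dopamine receptor (Homo sapiens); a lower number here means a stronger inhibitor, a higher number a weaker inhibitor. Among them compound 2 has the highest number of the three: compound 3 comes nearest, with a lower number that still lies beyond the usual scatter, and compound 1 is furthest away, with a number lower by a margin far beyond the scatter.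

Compound 4 `COc1ccccc1C1CCN(CNC(=O)c2cccc(C)c2)CC1` has not yet been measured. It differs from compound 2 in one place: a group of 8 heavy atoms (7 carbon, 1 oxygen; one six-membered aromatic ring of carbon only) in place of a group of 7 heavy atoms (5 carbon, 1 nitrogen, 1 oxygen; one six-membered aromatic ring with 1 hetero atom), on a saturated ring carbon. In words, a group of 8 heavy atoms (7 carbon, 1 oxygen; one six-membered aromatic ring of carbon only) takes the place of a group of 7 heavy atoms (5 carbon, 1 nitrogen, 1 oxygen; one six-membered aromatic ring with 1 hetero atom), on a saturated ring carbon.

Among the compounds with values here, no pair of measured compounds differs in a single place, so no measured step shows what such a change does here. The expectation is a step downward, beyond the scatter, from compound 2 to compound 4, estimated as a 12-fold lower number from compound 2 to compound 4 (1.08 log units; beyond the scatter). For compound 4 in this assay the estimate is 120 nM, with a range from 20 nM to 700 nM.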

Compound 4, inhibition constant: 1.3 nM
Compound 4: middle estimate off by 92-fold (1.97 log units), on the high side, and the stated range ends above it.
By their numbers in this assay, from the lowest: compound 4; then compound 1; then compound 3; then compound 2.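

In this assay the group on this saturated ring carbon, three ring bonds from the ring nitrogen, proves to matter greatly: putting 2-methoxyphenyl in place of the six-membered aromatic ring with 1 hetero atom gives a 1100-fold lower number from compound 2 to compound 4 (3.05 log units; beyond the scatter) and a large step beyond the usual scatter. The two groups have the same counts of hydrogen-bond donors and acceptors and no net charge, so those counts do not separate them, although their measured numbers lie far apart. No measurement is available that explains the size of this step.

It remains open whether the methoxy group itself matters, as a plain phenyl ring or a 2-ethoxyphenyl group at this position is not among the compounds shown. From the compounds shown here alone, it is also open whether the same swap would produce a step of similar size on the rest of compound 3.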